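Fluorine Added to the Phenyl of Compound 3

A few compounds are considered here, and "the series" means these few. Any claim that something is new, unique, unknown or untested is made for them only; others in the source may bear on it.

Three compounds share one core and differ only in the group on a saturated ring carbon. Compound 1 `CC1C(=O)N(C)c2cnc(Nc3ccc(S(N)(=O)=O)cc3)nc2N1C` gives 313 nM in an assay on Sf9 cells for inhibition of serine/threonine-protein kinase 4 (Homo sapiens), read by luminescence and ADP-Glo, with a stated time of 1 h, in the presence of a further agent that is not named here; a lower number here means a stronger inhibitor, a higher number a weaker inhibitor. Compound 2 `CN1C(=O)C(CC2CC2)N(C)c2nc(Nc3ccc(S(N)(=O)=O)cc3)ncc21` gives 211 nM in this assay, and compound 3 `CN1C(=O)C(c2ccccc2)N(C)c2nc(Nc3ccc(S(N)(=O)=O)cc3)ncc21` gives 383 nM. Compound 3 holds the highest of the three numbers, yet the step of a 1.2-fold higher number from compound 1 to compound 3 (0.09 log units; within the scatter) and the step of a 1.8-fold higher number from compound 2 to compound 3 (0.26 log units; within the scatter) both lie within the scatter, as does a 1.5-fold lower number from compound 1 to compound 2 (0.17 log units; within the scatter). Compound 4 `CN1C(=O)C(c2ccc(F)cc2)N(C)c2nc(Nc3ccc(S(N)(=O)=O)cc3)ncc21` is not yet measured; it differs from compound 3 by fluoro in place of hydrogen on an aromatic carbon. Within the data shown here, none of the measured steps touches this aromatic ring. The closest guide is that exchanging the whole group on the saturated ring carbon, as in a 1.2-fold higher number from compound 1 to compound 3 (0.09 log units; within the scatter) and a 1.8-fold higher number from compound 2 to compound 3 (0.26 log units; within the scatter), left the numbers within the scatter, so this smaller change further out is expected to move this assay by no step beyond the scatter, a 1.1-fold lower number from compound 3 to compound 4 (0.04 log units; within the scatter). Compound 4 is therefore expected to give about 350 nM, between 150 nM and 900 nM.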

Compound 4, half-maximal inhibitory concentration: 1770 nM
Compound 4: the middle estimate sits 5.1-fold (0.70 log units) below what was measured; the measured number lies above the stated range.
By their numbers in this assay, from the lowest: compounds 2, 1 and 3 (each within the scatter of the next); then compound 4.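

In this assay, swapping the whole group on the saturated ring carbon had stayed within the scatter, yet one fluoro on the phenyl ring, para to a large group, gives a step beyond it: a 4.6-fold higher number from compound 3 to compound 4 (0.66 log units; beyond the scatter). Among these compounds, measured against the compounds carrying other groups at that ring carbon, 4-fluorophenyl also stands clear, with an 8.4-fold higher number from compound 2 to compound 4 (0.92 log units; beyond the scatter) and a 5.7-fold higher number from compound 1 to compound 4 (0.75 log units; beyond the scatter), so this aromatic carbon matters more than the earlier compounds could show. Nothing available here explains why a single added fluorine moves the number this far.

From the compounds shown here alone, it remains open whether a chlorine atom, a methoxy group or an amine on that same aromatic carbon would also raise the number. Going by these compounds, it is equally open whether fluoro on another carbon of the phenyl ring would do so.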